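Notes on the series: trifluoromethyl in place of fluoro

A few compounds are considered here, and "the series" means these few. Any claim that something is new, unique, unknown or untested is made for them only; others in the source may bear on it.

Compound 1 `Cc1ccc(/C=C/c2cccc(F)c2)cc1` is the reference point. Within the data shown here, in an assay on HepG2 cells for activation of nuclear factor erythroid 2-related factor 2 (Homo sapiens), read by a luciferase reporter, with a stated time of 5 h (on this read-out higher numbers stand for an effect only at larger amounts of compound and lower numbers for an effect already at smaller amounts), compound 1 gives 800 nM, the lowest of the two numbers measured so far. Compound 2 `Cc1ccc(/C=C/c2ccc(F)c(F)c2)cc1` carries one more fluoro; in this assay compound 2 gives 2600 nM, and the step is a 3.3-fold higher number from compound 1 to compound 2 (0.51 log units; beyond the scatter). The next compound is compound 3 `Cc1ccc(/C=C/c2cccc(C(F)(F)F)c2)cc1`, which differs from compound 1 by trifluoromethyl in place of fluoro on an aromatic carbon, on an aromatic carbon of a six-membered aromatic ring of carbon only, meta to a group of 9 heavy atoms. Among the measured compounds shown here, no measured step exchanges fluoro for trifluoromethyl; the only step at hand shows a modest rise in number when a fluoro is added to that ring. For compound 3 a small rise in this assay is therefore expected, about a 1.6-fold higher number from compound 1 to compound 3 (0.21 log units; within the scatter), though a step within the scatter cannot be excluded. The estimate for compound 3 in this assay is 1300 nM, with a range from 450 nM to 3800 nM.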

Compound 3, half-maximal effective concentration: 1500 nM
Compound 3: the middle estimate sits 1.2-fold (0.06 log units) below what was measured; low and high end bracket the measured number.
By their numbers in this assay, from the lowest: compounds 1, 3 and 2 (each within the scatter of the next, the first and the last beyond it).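

In this assay, among these compounds, trifluoromethyl in place of fluoro on this aromatic carbon gives a 1.9-fold higher number from compound 1 to compound 3 (0.27 log units; within the scatter), the first exchange of one group for another at this place. Here 4 heavy atoms stand in place of 1 and the read-out stays within the usual scatter, whereas the only earlier step, fluoro in place of hydrogen with a 3.3-fold higher number from compound 1 to compound 2 (0.51 log units; beyond the scatter), lies beyond it. Nothing at hand gives a reason for either step.

Open, going by these compounds, is whether a group of another kind at this place, such as an amine, a carboxylic acid or a longer chain, would also stay within the scatter of compound 1. Also open, on these data alone, is whether trifluoromethyl would give a similar step at any other place on this ring.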